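The source may report more compounds than this note shows. Statements on the series, on what has been measured and on what is new or still open speak of the compounds shown alone.

Working notes on the series. Among the measured compounds shown here, compound 2 `CC(C)C(=O)N1C[C@@H](O[C@H](C)c2cc(C(F)(F)F)cc(C(F)(F)F)c2)[C@H](c2ccc(F)cc2)C1` stands at the lower of the two numbers so far, a gap that is within the scatter: in an assay on CHO cells for displacement of a labelled ligand from Substance-P receptor (Homo sapiens) (a higher number here means a weaker inhibitor, a lower number a stronger inhibitor), compound 2 gives 0.15 nM, and compound 1 `C[C@@H](O[C@@H]1CN(C=O)C[C@H]1c1ccc(F)cc1)c1cc(C(F)(F)F)cc(C(F)(F)F)c1` gives 0.24 nM. For the measured compounds named here, the single measured step at the carbonyl carbon, a 1.6-fold lower number from compound 1 to compound 2 (0.20 log units; within the scatter), did not leave the scatter. Compound 3 `C[C@@H](O[C@@H]1CN(C(=O)[C@@H]2CCC(=O)N2C)C[C@H]1c1ccc(F)cc1)c1cc(C(F)(F)F)cc(C(F)(F)F)c1` changes the same position again: 1-methyl-5-oxopyrrolidin-2-yl in place of isopropyl on a carbonyl carbon. Going by the values given here, only the step from compound 1 to compound 2 bears on this change, and it was small, so the carbonyl substituent has not so far shifted this assay beyond the scatter. The entering group, with its ring and its hydrogen-bond acceptor, is not covered by that pair, so the expectation rests on a thin base. The step expected from the change, a 1.3-fold higher number from compound 2 to compound 3 (0.12 log units; within the scatter), is estimated to stay within the scatter. Compound 3 is therefore expected to give about 0.2 nM in this assay, in a range from 0.07 nM to 0.6 nM.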

Compound 3, half-maximal inhibitory concentration: 0.12 nM
The estimate for compound 3 lay 1.7-fold (0.22 log units) above the measured number; the range from low to high includes it.
By their numbers in this assay, from the lowest: compounds 3, 2 and 1 (each within the scatter of the next).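

Putting 1-methyl-5-oxopyrrolidin-2-yl in place of isopropyl on the carbonyl carbon brings in a five-membered ring, a hydrogen-bond acceptor and a defined stereocentre, yet this assay shows a 1.3-fold lower number from compound 2 to compound 3 (0.10 log units; within the scatter) and so does not leave the scatter. The comparison with hydrogen at the same place gives a 2.0-fold lower number from compound 1 to compound 3 (0.30 log units; within the scatter), also within the scatter. Across hydrogen, isopropyl and 1-methyl-5-oxopyrrolidin-2-yl, this position has therefore not moved the number beyond the scatter in any measured step, and nothing available here explains that tolerance.

From the compounds shown here alone, whether the position stays this flat with an amine or a carboxylic acid on the carbonyl carbon remains open. Also open, going by these compounds, is whether the opposite configuration at the stereocentre of 1-methyl-5-oxopyrrolidin-2-yl would give a similar number.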